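From Carbamoyl to Pyrazolylethoxy on a Shared Core

This account rests on a few compounds, and the source may have more. Where it says the series, first, only, none or still open, it means among the compounds named here.

Compound 2 `Cc1nn(-c2ncnc3nc[nH]c23)c2c1C(C(=O)N(C)c1nccs1)CC(=O)N2` stands highest of the two numbers in hand: in a functional assay on HEK293 cells for agonist activity at G-protein coupled receptor 39 (Homo sapiens), read by scintillation proximity assay and inositol phosphate accumulation, with a stated time of 75 min (on this read-out higher numbers stand for an effect only at larger amounts of compound and lower numbers for an effect already at smaller amounts), compound 2 gives 3300 nM, while compound 1 `Cc1nn(-c2ncnc3nc[nH]c23)c2c1C(OCc1ccc(Cl)cc1Cl)CC(=O)N2` gives 243 nM. Going by the values given here, the only measured step, a 14-fold higher number from compound 1 to compound 2 (1.13 log units; beyond the scatter), bears on the change now considered. Compound 3 `Cc1nn(-c2ncnc3nc[nH]c23)c2c1C(OCCn1cccn1)CC(=O)N2` carries 2-(1H-pyrazol-1-yl)ethoxy in place of methyl(1,3-thiazol-2-yl)carbamoyl on a saturated ring carbon. Because the step of a 14-fold higher number from compound 1 to compound 2 (1.13 log units; beyond the scatter) was large, and the entering 2-(1H-pyrazol-1-yl)ethoxy resembles the (2,4-dichlorobenzyl)oxy of compound 1 more than the carbamoyl it replaces, a partial return toward lower numbers is expected. The estimated step is a 3.7-fold lower number from compound 2 to compound 3 (0.56 log units; beyond the scatter). Compound 3 is expected to give 900 nM, within 200 nM to 4000 nM.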

Compound 3, half-maximal effective concentration: 2270 nM
The estimate for compound 3 lay 2.5-fold (0.40 log units) below the measured number; the range from low to high includes it.
By their numbers in this assay, from the lowest: compound 1; then compounds 3 and 2 (each within the scatter of the next).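

Replacing methyl(1,3-thiazol-2-yl)carbamoyl with 2-(1H-pyrazol-1-yl)ethoxy on this saturated ring carbon gives a 1.5-fold lower number from compound 2 to compound 3 (0.16 log units; within the scatter) and so does not recover the lower number of compound 1. With the oxygen kept on that carbon, (1H-pyrazol-1-yl)methyl in place of 2,4-dichlorophenyl gives a 9.3-fold higher number from compound 1 to compound 3 (0.97 log units; beyond the scatter) and so ties the gap to the far end of the group. No measurement at hand explains either step. As far as these compounds go, whether an unsubstituted benzyl group would keep the lower number of compound 1 stays open, as does the effect of an amine or a carboxylic acid at the end of the chain.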